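The source may report more compounds than this note shows. Statements on the series, on what has been measured and on what is new or still open speak of the compounds shown alone.

Compound 1 `NC(=S)N1CCc2c(OCCCCCOc3ccc(Cl)cc3)cccc21`: in an ADME assay on Huh-7 cells (Homo sapiens) for cytotoxicity (on this read-out lower numbers stand for higher toxicity in this test and higher numbers for lower toxicity in this test), compound 1 gives > 50000 nM, a limit of the assay.
Compound 2 `O=C(NC(=S)N1CCc2c(OCCCCCOc3ccc(Cl)cc3)cccc21)c1ccc(Br)cc1`: in this assay compound 2 gives 29100 nM.
Compound 3 `CN(C)c1ccc(C(=O)NC(=S)N2CCc3c(OCCCCCOc4ccc(Cl)cc4)cccc32)cc1`: in this assay compound 3 gives > 50000 nM, again a limit of the assay.

Compound 3 thus stands at the upper end of what the test can report, and the limit of > 50000 nM in this assay, at which 2 of the 3 values shown sit, shows that it shares this position with compound 1. Going by the values given here, the only numbered step that touches compound 3 is an at least 1.7-fold higher number from compound 2 to compound 3 (0.23 log units; that floor lies within the scatter), a change that reaches at least the floor given and may be larger. The step that the two limits leave unreadable from compound 1 to compound 3 cannot be read because both ends are limits. The step of an at least 1.7-fold lower number from compound 1 to compound 2 (0.23 log units; that floor lies within the scatter) is the one numbered move away from the limit among the three compounds.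

Compound 4 `O=S(=O)(NC(=S)N1CCc2c(OCCCCCOc3ccc(Cl)cc3)cccc21)c1ccccc1` differs from compound 3 by phenylsulfonyl in place of (4-(dimethylamino)phenyl)carbonyl on an amide-type nitrogen. Among the compounds with values here, no measured pair shows a sulfonyl group on this nitrogen, so the closest guide is that swapping one group on this nitrogen for another moved the number by about the size seen from compound 1 to compound 2. The step of an at least 1.2-fold lower number from compound 3 to compound 4 (0.09 log units; that floor lies within the scatter) is therefore expected to be small, and a limit is about as likely as a number. Compound 4 is estimated at 40000 nM, within 15000 nM to 100000 nM.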

Compound 4, half-maximal cytotoxic concentration: > 50000 nM
Compound 4: a limit, no number; the forecaster's own chance of this, stated with the estimate: 45%; middle value at least 1.2-fold (0.09 log units) from the limit.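

The earlier compounds shown here carried only hydrogen or a carbonyl-linked group on this amide-type nitrogen, and compound 4 adds a sulfonyl-linked group there: in this assay compound 4 gives > 50000 nM, which is a limit of the assay and not a number. Swapping (4-bromophenyl)carbonyl for phenylsulfonyl gives an at least 1.7-fold higher number from compound 2 to compound 4 (0.23 log units; that floor lies within the scatter), the one step here that can be read, while the steps to compound 4 from compound 1 and from compound 3 join two limits and cannot be read. Hydrogen, (4-(dimethylamino)phenyl)carbonyl and now phenylsulfonyl on this nitrogen all end at the same ceiling, leaving compound 2 as the only one of the four with a measured number: the limit of > 50000 nM in this assay, at which 3 of the 4 values shown sit.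

With three compounds at one limit, the compounds shown cannot place those three groups in any order against one another. Also open, as far as these compounds go, is whether a bromo group on the ring of phenylsulfonyl, as in (4-bromophenyl)sulfonyl, would bring a number into the test as the bromo group of compound 2 sits with one, and what a small methylsulfonyl group would give on this nitrogen.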